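This account rests on a few compounds, and the source may have more. Where it says the series, first, only, none or still open, it means among the compounds named here.

Measured compounds:
- compound 1, `COc1cc(/C=C2\CCC/C(=C\c3ccccc3[N+](=O)[O-])C2=O)cc(OC)c1OC`, gives 402 nM in a functional assay on CCRF-CEM cells (Homo sapiens) for cytotoxicity, with a stated time of 72 h; a lower number here means a stronger inhibitor, a higher number a weaker inhibitor
- compound 2, `O=C1/C(=C/c2ccccc2)CCC/C1=C\c1cccc([N+](=O)[O-])c1`, gives 2290 nM in this assay
- compound 3, `Cc1ccc(/C=C2\CCC/C(=C\c3ccc([N+](=O)[O-])cc3)C2=O)cc1`, gives 8530 nM in this assay

All three share one core, a ring carrying a carbonyl with two aromatic arms attached through double bonds, and each carries a nitro group on one arm. Among the three numbers, compound 2 stands second highest: compound 1 lies lower than it and compound 3 lies higher, and both of those gaps are beyond the usual scatter of such measurements.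

Compound 4, `O=C1/C(=C/c2ccc(Cl)cc2)CCC/C1=C\c1cccc([N+](=O)[O-])c1`, is not yet measured. It differs from compound 2 in one place: chloro in place of hydrogen on an aromatic carbon. Going by the values given here, no pair of measured compounds shows this exact change, so there is nothing directly to lean on. The nearest comparison, compound 3 with its methyl on the same arm, differs in too many other places to guide the step. The expectation is therefore modest: a step from compound 2 to compound 4 of a 1.1-fold lower number from compound 2 to compound 4 (0.06 log units; within the scatter), within or near the scatter. Compound 4 is expected to give about 2000 nM in this assay, within a range from 700 nM to 6000 nM.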

Compound 4, half-maximal inhibitory concentration: 1750 nM
The estimate for compound 4 lay 1.1-fold (0.06 log units) above the measured number; the measured number falls inside the stated range.
By their numbers in this assay, from the lowest: compound 1; then compounds 4 and 2 (each within the scatter of the next); then compound 3.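

In this assay, going by these compounds alone, the change from phenyl to 4-chlorophenyl gives a 1.3-fold lower number from compound 2 to compound 4 (0.12 log units; within the scatter) and is the first comparison here between two compounds that differ in only one place. It shows that, on this aromatic carbon para to a large group, chloro can take the place of hydrogen without a shift that can be told apart from ordinary repeat-to-repeat variation. No measurement here offers an explanation for this result.

Going by these compounds, whether the same holds for larger or very different groups at this carbon, such as an amine or a carboxylic acid, remains open. Also open, on these data alone, is whether chloro elsewhere on this ring, or on the ring carrying the nitro group, would leave the number within the scatter too.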